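The source may hold more compounds than are shown below. What is called first, only, known or untested is meant among the compounds shown, and "the series" means these compounds.

Working notes on the series. Compound 1 `COc1ccc2occ(CSC(=S)N(C(C)C)C(C)C)c(=O)c2c1` carries diisopropylamino on the thiocarbonyl carbon. In a functional assay on MCF7 cells (Homo sapiens) for antiproliferative activity, read by MTT assay, with a stated time of 72 h (on this read-out lower numbers stand for stronger inhibition and higher numbers for weaker inhibition), compound 1 gives no number, only a limit, > 40000 nM. Compound 2 `O=c1cc(CSC(=S)N2CCCC2)oc2cc(Cl)ccc12` is likewise known in this assay only as a limit, > 25000 nM. Compound 3 `O=c1c(SC(=S)N2CCCCC2)coc2ccc(Cl)cc12` also reaches only a limit in this assay, > 25000 nM. Within the data shown here, compound 1 therefore stands where every measured member of the series stands: at a limit of the read-out, whether the limit of > 40000 nM in this assay, at which 1 of the 3 values shown sits, or (the limit of > 25000 nM in this assay, at which 2 of the 3 values shown sit), and no measured compound sets a number from which a step could be sized or a direction read.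

Compound 4 `COc1ccc2occ(CSC(=S)N3CCCC3)c(=O)c2c1` is still to be measured in this assay. It differs from compound 1 by pyrrolidin-1-yl in place of diisopropylamino on a thiocarbonyl carbon. Among the measured compounds shown here, no step between measured compounds covers this exchange. Compound 2 carries pyrrolidin-1-yl on its own thiocarbonyl carbon and its result in this assay was a limit. On this evidence no step beyond the scatter is expected in this assay in either direction. The step from compound 1 to compound 4 is expected to be a number no higher from compound 1 to compound 4 (the limit leaves the size open), which amounts to no change. Compound 4 is thus expected near 40000 nM, with a range of 15000 nM to 100000 nM, and most likely to be reported again as a limit rather than a number.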

Compound 4, half-maximal inhibitory concentration: 34100 nM
Estimate against measurement, compound 4: 1.2-fold (0.07 log units) above; the range from low to high includes it.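

In this assay, among these compounds, compound 4 gives 34100 nM, the first number rather than a limit, so the thiocarbonyl carbon on the core of compound 1 now has a value from which later exchanges can be sized. Pyrrolidin-1-yl in place of diisopropylamino on a thiocarbonyl carbon gives an at least 1.1-fold lower number from compound 1 to compound 4 (0.06 log units; that floor lies within the scatter), so this exchange of an open group for a five-membered ring shows no step that clears the scatter, although a larger step is not excluded. Only a floor can be given for the step because compound 1 rests at a limit of the read-out and not at a number: the limit of > 40000 nM in this assay, at which 1 of the 4 values shown sits.

The true size of the step stays open, since the compounds shown give no number for diisopropylamino on this core. Also open, going by these compounds, is whether morpholin-4-yl or dimethylamino on the same thiocarbonyl carbon of the core of compound 1 would move the value in this assay in either direction.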